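Series notes: from sulfanyl to (2-hydroxyethyl)amino on the core

The compounds below may be only part of what the source reports. "The series", "measured", "known", "first", "only" and "open" are said of these compounds alone.

Of the compounds shown here, three sharing one core have been measured in a functional assay (Homo sapiens) for inhibition of Nucleic Acid, tested at 100 uM; on this read-out lower numbers stand for less inhibition and higher numbers for more inhibition at the one concentration tested (going by the name of the read-out). Compound 1 `CCCCCCNc1[nH]ccc2ncnc1-2` gives 53%. Compound 2 `Clc1[nH]ccc2ncnc1-2` gives 6%, and compound 3 `Sc1[nH]ccc2ncnc1-2` gives 26%. Compound 3 thus stands second of the three numbers: its nearest neighbour is compound 2, which sits beyond the scatter below it, and compound 1 sits beyond the scatter above it. Going by the values given here, the only single-place step among the measured compounds is a number 20 percentage points higher from compound 2 to compound 3 (beyond the scatter), a modest rise in this assay.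

Compound 4 `OCCNc1[nH]ccc2ncnc1-2` is to be measured in this assay. It differs from compound 3 as follows: (2-hydroxyethyl)amino in place of sulfanyl on an aromatic carbon. Among the compounds with values here, no measured step covers exactly this exchange. The step that bears on it most closely is a number 20 percentage points higher from compound 2 to compound 3 (beyond the scatter), which shows that exchanging the group at this carbon moves the read-out by a modest amount. Within the data shown here, the pair of compound 3 and compound 1 also informs it, since compound 1 carries an amino substituent at the same carbon and gives 53%, whereas compound 3 gives 26%, though no single-place step links them. An amino substituent is therefore expected to lift the number somewhat, with a step of a number 10 percentage points higher from compound 3 to compound 4 (within the scatter) estimated, but not as far as compound 1, which gives 53%. Compound 4 is estimated at 36%, within a range of 16% to 58%.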

Compound 4, a percentage reported as inhibition, at one concentration (the size of the read-out at that concentration, not a potency): 3%
Compound 4: the middle estimate sits 33 percentage points above what was measured; the whole stated range lies above it.
By their numbers in this assay, from the lowest: compounds 4 and 2 (each within the scatter of the next); then compound 3; then compound 1.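

In this assay, an amino link at this aromatic carbon does not by itself raise the read-out: (2-hydroxyethyl)amino in place of sulfanyl gives a number 23 percentage points lower from compound 3 to compound 4 (beyond the scatter) and so reverses the direction expected from compound 1. Against chloro, the same exchange gives a number 3 percentage points lower from compound 2 to compound 4 (within the scatter) and leaves compound 4 and compound 2 indistinguishable here, so this group does not share the rise seen with sulfanyl in place of chloro. The change further out on the chain matters far more, since hydroxy in place of butyl on a saturated chain carbon, two bonds along the chain from a nitrogen on an aromatic ring, gives a number 50 percentage points lower from compound 1 to compound 4 (beyond the scatter) and shows that the read-out at this position depends on what the nitrogen carries rather than on the nitrogen alone.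

No measurement at hand gives a reason for any of these steps. The step between compound 1 and compound 4 changes chain length and chain end together, so an ethylamino or hexylamino group with and without a terminal hydroxy, or a 2-methoxyethylamino group, would be needed to separate the two.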